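Notes: tert-butoxy in place of cyclohexyl

The source may report more compounds than this note shows. Statements on the series, on what has been measured and on what is new or still open speak of the compounds shown alone.

- In a physicochemical assay for lipophilicity, at pH 7.4 (a higher number here means a more lipophilic compound, a lower number a more polar compound), compound 1 `Cc1cc(C(=O)NC(C)C)nn1Cc1cc(Cl)ccc1OCc1ccccc1` gives > 3.7 as a limit of the assay.
- In this assay compound 2 `Cc1cc(NC(=O)C2CCCO2)nn1Cc1cc(Cl)ccc1OCc1ccccc1` gives > 3.7 as a limit of the assay.
- In this assay compound 3 `Cc1cc(NC(=O)C2CCCCC2)nn1Cc1cc(Cl)ccc1OCC(C)C` gives > 3.7 as a limit of the assay.

Compound 3 has only the limit > 3.7 to stand on and no number. What the measurements show across the series is the limit of > 3.7 in this assay, at which 3 of the 3 values shown sit, and nothing finer.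

The change from compound 3 to compound 4 `Cc1cc(NC(=O)OC(C)(C)C)nn1Cc1cc(Cl)ccc1OCC(C)C` is tert-butoxy in place of cyclohexyl on a carbonyl carbon and reads in short as tert-butoxy in place of cyclohexyl on a carbonyl carbon.

Going by the values given here, the only measured step is a step that the two limits leave unreadable from compound 1 to compound 2 and it gives no size to carry over. Among the compounds with values here, it also concerns a different exchange, so no measured step bears directly on this one. The data therefore support no direction for the change in this assay and no step beyond the scatter is expected. The estimated step that the limit leaves unreadable from compound 3 to compound 4 is to be read in that light, as an expectation set against a limit and not against a number.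

In this assay compound 4 is expected at 3.9 within an estimated range of 3.4 to 4.5. Compound 4 too may well end up with only a limit.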

Compound 4, distribution coefficient: > 3.7
Compound 4 was reported as a limit; the forecaster's own chance of this, stated with the estimate: 75%; the middle value is on the limit's open side.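

No step can be read from compound 3 to compound 4 in this assay, because both results are limits of the assay and not numbers: the limit of > 3.7 in this assay, at which 4 of the 4 values shown sit.

The compounds shown leave open where any of them truly lies in this assay, and whether tert-butoxy in place of cyclohexyl on a carbonyl carbon shifts the distribution coefficient at all.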